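This account rests on a few compounds, and the source may have more. Where it says the series, first, only, none or still open, it means among the compounds named here.

Compound 1, `COC(=O)N1[C@@H]2C=C[C@@](OC)(C(=O)c3c2cc(OC)c(OC)c3OCc2ccc(Cl)cc2)N1C(=O)OC`, was tested in an ADME assay on KB cells (Homo sapiens) for cytotoxicity (on this read-out higher numbers stand for an effect only at larger amounts of compound and lower numbers for an effect already at smaller amounts), where compound 1 gives 55.9 ug/mL. Two related compounds were measured in the same way: compound 2, `CCOC(=O)N1[C@@H]2C=C[C@@](OC)(C(=O)c3c2cc(OC)c(OC)c3OCc2ccc(Cl)cc2)N1C(=O)OCC`, gives 99.9 ug/mL, and compound 3, `CCCCOc1c(OC)c(OC)cc2c1C(=O)[C@]1(OC)C=C[C@H]2N(C(=O)OCC)N1C(=O)OCC`, gives 76 ug/mL. Compound 3 differs from compound 2 by propyl in place of 4-chlorophenyl on a saturated chain carbon bound to an oxygen on an aromatic ring, and this gave a 1.3-fold lower number from compound 2 to compound 3 (0.12 log units; within the scatter). Compound 4, `CCCCOc1c(OC)c(OC)cc2c1C(=O)[C@]1(OC)C=C[C@H]2N(C(=O)OC)N1C(=O)OC`, is the analogous partner of compound 1: it differs from compound 1 by propyl in place of 4-chlorophenyl on a saturated chain carbon bound to an oxygen on an aromatic ring, the same change at the same place. How the core of compound 1 differs from that of compound 2 is not broken down here. Because the earlier step of a 1.3-fold lower number from compound 2 to compound 3 (0.12 log units; within the scatter) stayed within the scatter, a step of similar size, a 1.2-fold lower number from compound 1 to compound 4 (0.07 log units; within the scatter), is expected here. Compound 4 is therefore estimated at 48 ug/mL, plausibly between 25 ug/mL and 95 ug/mL.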

Compound 4, concentration for half-maximal effect: > 300 ug/mL
Compound 4: a limit, no number; the forecaster's own chance of this, stated with the estimate: 5%; at least 6.2-fold (0.79 log units) between middle value and limit.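

Carrying the change of 4-chlorophenyl to propyl onto the core of compound 1 gave an at least 5.3-fold higher number from compound 1 to compound 4 (0.72 log units; beyond the scatter), so the result on one core did not predict the result on the other: the same change on two cores in this assay, a 1.3-fold lower number (0.12 log units; within the scatter) from compound 2 to compound 3 and an at least 5.3-fold higher number (0.72 log units; beyond the scatter) from compound 1 to compound 4, at least 7.0-fold (0.84 log units) apart, beyond the scatter of two such steps. Going by these compounds, compound 4 gives > 300 ug/mL in this assay, which is a limit of the assay and not a number, so the full size of this step remains unknown: the limit of > 300 ug/mL in this assay, at which 1 of the 4 values shown sits. These two pairs do not show which feature of the cores goes with the gap, and they give no rule for any further core.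

On these data alone, it remains open how a longer chain such as hexyl or a plain benzyl group would behave on each core. Also open, as far as these compounds go, is whether a core bearing tert-butyl carbamates would follow compound 1 or compound 2.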